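The source may hold more compounds than are shown below. What is called first, only, known or untested is meant among the compounds shown, and "the series" means these compounds.

Measured so far in a functional assay on MCF7 cells (Homo sapiens) for inhibition, read by MTT assay, with a stated time of 48 h; a higher number here means a weaker inhibitor, a lower number a stronger inhibitor:
compound 1 `Fc1ccc(CSc2nnc(-c3ccncc3)n2-c2ccccc2)c(F)c1`: 14100 nM
compound 2 `O=[N+]([O-])c1ccccc1CSc1nnc(-c2ccncc2)n1-c1ccccc1`: > 50000 nM

For compound 2 the reading is a limit of the assay and not a number; compound 2 is recorded only as > 50000 nM, sitting at the limit of > 50000 nM in this assay, at which 1 of the 2 values shown sits. From the compounds shown here alone, compound 2 therefore stands at the weak end of the two values shown, and its true position above that limit is unknown.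

Going by the values given here, the one measured step, an at least 3.5-fold higher number from compound 1 to compound 2 (0.54 log units; beyond the scatter), runs toward weaker inhibition when 2-nitrophenyl replaces 2,4-difluorophenyl. Compound 3 `O=[N+]([O-])c1cccc(CSc2nnc(-c3ccncc3)n2-c2ccccc2)c1` carries the change (3-nitrophenyl in place of 2-nitrophenyl on a saturated chain carbon bound to a sulfur); the two have the same atoms, joined differently. Among the compounds with values here, no measured step compares 2-nitrophenyl with 3-nitrophenyl, so the step from compound 1 shows only that a nitrophenyl at this place gives a weak inhibitor and offers no direction for the move. Compound 3 is expected to remain near the limit, with an at least 1.1-fold lower number from compound 2 to compound 3 (0.04 log units; that floor lies within the scatter) as the estimated step, not beyond the scatter. Compound 3 is estimated at 45000 nM, between 15000 nM and 150000 nM, with a real chance that again only a limit is reported.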

Compound 3, half-maximal inhibitory concentration: 18300 nM
Compound 3: the middle estimate sits 2.5-fold (0.39 log units) above what was measured; low and high end bracket the measured number.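

In this assay, exchanging 2-nitrophenyl for 3-nitrophenyl on a saturated chain carbon bound to a sulfur gives an at least 2.7-fold lower number from compound 2 to compound 3 (0.43 log units; beyond the scatter), so the weak reading at this place belongs to the 2-nitrophenyl isomer and not to nitrophenyl as such. The reading of compound 2 is a limit and not a number: the limit of > 50000 nM in this assay, at which 1 of the 3 values shown sits. Set against 2,4-difluorophenyl, the 3-nitrophenyl group gives a 1.3-fold higher number from compound 1 to compound 3 (0.11 log units; within the scatter), so these two groups cannot be told apart in this assay.

Open, from the compounds shown here alone, is how 4-nitrophenyl, an aminophenyl or a phenyl carrying a carboxylic acid would read at this place. Also open, going by these compounds, is whether a longer chain at the saturated carbon bound to a sulfur would keep the gap seen for the two nitrophenyl isomers.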